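Amine to Sulfonamide on the Anilide Ring

The source may report more compounds than this note shows. Statements on the series, on what has been measured and on what is new or still open speak of the compounds shown alone.

Compound 1 `CNC(=O)c1ccc(NC(=O)c2cn(Cc3c(F)cccc3F)c3ccc(=O)[nH]c3c2=O)cc1` gives 29 nM in an in vitro assay on Sf21 cells for inhibition of high affinity 3',5'-cyclic-AMP phosphodiesterase 7A (Homo sapiens), read by scintillation proximity assay, with a stated time of 30 min; a higher number here means a weaker inhibitor, a lower number a stronger inhibitor.
Compound 2 `CN(C)c1ccc(NC(=O)c2cn(Cc3c(F)cccc3Cl)c3ccc(=O)[nH]c3c2=O)cc1` gives 39 nM in this assay.

Compound 2 and compound 1 lie within the usual scatter of each other, so neither stands apart on the numbers shown. Compound 3 `O=C(Nc1ccc(S(=O)(=O)Nc2nccs2)cc1)c1cn(Cc2c(F)cccc2Cl)c2ccc(=O)[nH]c2c1=O` has not been measured. It differs from compound 2 by (1,3-thiazol-2-yl)sulfamoyl in place of dimethylamino on an aromatic carbon. Among the measured compounds shown here, no step between measured compounds is known here, so the expectation rests on the change alone: a modest move toward a higher number in this assay, as a 1.8-fold higher number from compound 2 to compound 3 (0.25 log units; within the scatter), is estimated. Compound 3 is expected to give 70 nM, within a range of 15 nM to 300 nM.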

Compound 3, half-maximal inhibitory concentration: 32 nM
The estimate for compound 3 lay 2.2-fold (0.34 log units) above the measured number; low and high end bracket the measured number.
By their numbers in this assay, from the lowest: compounds 1, 3 and 2 (each within the scatter of the next).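

In this assay, (1,3-thiazol-2-yl)sulfamoyl in place of dimethylamino gives a 1.2-fold lower number from compound 2 to compound 3 (0.09 log units; within the scatter), which lies within the scatter. This place on the six-membered aromatic ring, para to a large group, therefore tolerates a much larger group that brings in a five-membered aromatic ring, with no change the assay can resolve. Nothing available explains why the number holds. From the compounds shown here alone, whether the five-membered ring matters stays open, and a plain sulfamoyl group would test that. A carboxylic acid or a primary amine at this place also remains an open case.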